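Swapping chloro for methoxy on a thiophene-linked biaryl amidine

This account rests on a few compounds, and the source may have more. Where it says the series, first, only, none or still open, it means among the compounds named here.

Measured so far:
- compound 1 `N=C(N)c1ccc(-c2ccc(-c3ccc(F)cc3)s2)cc1`: 1580 nM
- compound 2 `N=C(N)c1ccc(-c2ccc(-c3ccc(Cl)cc3)s2)cc1F`: 171 nM
- compound 3 `COc1cc(OC)cc(-c2ccc(-c3ccc(C(=N)N)c(F)c3)s2)c1`: 173 nM

Of the compounds shown here, three sharing one core have been tested in a functional assay on HCT-116 cells (Homo sapiens) for inhibition, read by sulforhodamine B assay, with a stated time of 48 h; a lower number here means a stronger inhibitor of growth, a higher number a weaker inhibitor of growth. Compound 2 gives 171 nM, the lowest of the three numbers, though compound 3 at 173 nM sits within the scatter of it, so no order between those two can be read. Compound 1 at 1580 nM lies clearly beyond the scatter above compound 2.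

Compound 4 `COc1ccc(-c2ccc(-c3ccc(C(=N)N)c(F)c3)s2)cc1` is the next compound, not yet measured. Relative to compound 2 it differs in one place: methoxy in place of chloro on an aromatic carbon. Since compound 3, which also bears methoxy groups on that ring, gives 173 nM, no step beyond the scatter is expected in this assay; the estimated change is a 1.5-fold higher number from compound 2 to compound 4 (0.16 log units; within the scatter). Compound 4 is expected to give 250 nM, with a plausible range from 100 nM to 700 nM.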

Compound 4, concentration for 50% growth inhibition: 3040 nM
Beside the measured number, compound 4's estimate is 12-fold (1.08 log units) below it; measured number above the stated range.
By their numbers in this assay, from the lowest: compounds 2 and 3 (each within the scatter of the next); then compounds 1 and 4 (each within the scatter of the next).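

In this assay, the change from chloro to methoxy at this position, para to a large group, is far from neutral: it gives an 18-fold higher number from compound 2 to compound 4 (1.25 log units; beyond the scatter). This single swap on an aromatic carbon is therefore enough to separate a low number from a high one, so the two groups cannot be treated as interchangeable here. No measurement shown explains the step.

The compounds shown leave open how a hydroxyl, an amine or a methyl at this same place would compare with chloro and methoxy.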